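The source may hold more compounds than are shown below. What is called first, only, known or untested is meant among the compounds shown, and "the series" means these compounds.

Among the measured compounds shown here, compound 2, `Cc1ccccc1-c1nn(-c2ccc(F)cc2F)cc1CNCCN1CCN(C)CC1`, is one of only two compounds with a measured toxicity value. In an ADME assay on Huh-7 cells (Homo sapiens) for cytotoxicity (on this read-out lower numbers stand for higher toxicity in this test and higher numbers for lower toxicity in this test), compound 2 gives > 20000 nM, which is a limit of the assay rather than a measured number. The other measured compound, compound 1, `Cc1ccccc1-c1nn(-c2ccc(F)cc2F)cc1CNCCN1CCCCC1`, differs from compound 2 in a single group. In this assay compound 1 also gives > 20000 nM, again a limit and not a number. The step that the two limits leave unreadable from compound 1 to compound 2 therefore cannot be read, neither in size nor in direction, and the only thing the two results establish is the limit of > 20000 nM in this assay, at which 2 of the 2 values shown sit.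

Compound 3, `CCN(CC)CCCNCc1cn(-c2ccc(F)cc2F)nc1-c1ccccc1C`, has not yet been measured. Its change from compound 2 is (diethylamino)methyl in place of 4-methylpiperazin-1-yl on a saturated chain carbon, two bonds along the chain from an amine nitrogen. For the measured compounds named here, no measured step speaks to this particular change, and since both known values sit at the same limit, there is no basis for expecting a step beyond the usual scatter in this assay in either direction. On that footing, compound 3 is expected to come out at about 25000 nM, within a range from 10000 nM to 60000 nM. The expected step that the limit leaves unreadable from compound 2 to compound 3 is thus essentially none, with a good chance that only a limit is reported once more.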

Compound 3, half-maximal cytotoxic concentration: > 20000 nM
Compound 3 was reported as a limit; the forecaster's own chance of this, stated with the estimate: 75%; the middle value lies beyond the limit too.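

In this assay compound 3 gives > 20000 nM as a limit and not a number, so the steps linking compound 1, compound 2 and compound 3 cannot be read. These compounds leave open what true value any of them has, and whether exchanging piperidin-1-yl, 4-methylpiperazin-1-yl and (diethylamino)methyl changes the toxicity read-out at all.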